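The compounds below may be only part of what the source reports. "The series", "measured", "known", "first", "only" and "open" are said of these compounds alone.

Compound 1 `COc1cc(OC)c(-c2coc3cc(OCc4ccccc4C(F)(F)F)ccc3c2=O)cc1OC` carries a 2-(trifluoromethyl)benzyl on the shared core and in a functional assay on HCT-116 cells (Homo sapiens) for antiproliferative activity, read by MTT assay, with a stated time of 24 h (on this read-out lower numbers stand for stronger inhibition and higher numbers for weaker inhibition), compound 1 gives 4760 nM. Compound 2 `COc1cc(OC)c(-c2coc3cc(OCc4ccc(Cl)cc4)ccc3c2=O)cc1OC` gives 4450 nM in this assay, so the two numbers stand together, with a 1.1-fold lower number from compound 1 to compound 2 (0.03 log units; within the scatter). Compound 3 `COc1cc(OC)c(-c2coc3cc(OCc4ccc(C(F)(F)F)cc4)ccc3c2=O)cc1OC` differs from compound 1 by 4-(trifluoromethyl)phenyl in place of 2-(trifluoromethyl)phenyl on a saturated chain carbon bound to an oxygen on an aromatic ring. Within the data shown here, the one step that bears on it, a 1.1-fold lower number from compound 1 to compound 2 (0.03 log units; within the scatter), exchanges the same ring with no shift beyond the scatter, so no step beyond the scatter is expected here either, a 1.1-fold lower number from compound 1 to compound 3 (0.02 log units; within the scatter). Compound 3 is therefore estimated at 4500 nM in this assay, within 2000 nM to 10000 nM.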

Compound 3, half-maximal inhibitory concentration: 2440 nM
Beside the measured number, compound 3's estimate is 1.8-fold (0.27 log units) above it; the measured number falls inside the stated range.
By their numbers in this assay, from the lowest: compounds 3, 2 and 1 (each within the scatter of the next).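

In this assay the change from 2-(trifluoromethyl)benzyl to 4-(trifluoromethyl)benzyl, the same atoms joined differently, gives a 2.0-fold lower number from compound 1 to compound 3 (0.29 log units; within the scatter) and so does not separate the two placements of trifluoromethyl. Trifluoromethyl in place of chloro on an aromatic carbon gives a 1.8-fold lower number from compound 2 to compound 3 (0.26 log units; within the scatter) and so does not separate these two groups either, which leaves all three compounds together at this position. No supporting data are available to account for these numbers.

The compounds shown leave open whether an amine or a carboxylic acid on this ring would give a step beyond the scatter. The same question stands for a longer chain in place of the saturated chain carbon.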